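This account rests on a few compounds, and the source may have more. Where it says the series, first, only, none or still open, it means among the compounds named here.

Among the measured compounds shown here, in a functional assay (trachea) with Cavia porcellus as the target (on this read-out lower numbers stand for stronger inhibition and higher numbers for weaker inhibition), compound 2 `CCCCCCCCn1nc(-c2cccnc2)c2ccccc2c1=O` gives 21900 nM, the higher of the two numbers so far, with compound 1 `CCn1nc(-c2cccnc2)c2ccccc2c1=O` at 1320 nM. Compound 3 `C=CCn1nc(-c2cccnc2)c2ccccc2c1=O` differs from compound 2 by vinyl in place of heptyl on a saturated chain carbon bound to an aromatic nitrogen, or octyl to allyl. For the measured compounds named here, the one measured step bearing on this is a 17-fold higher number from compound 1 to compound 2 (1.22 log units; beyond the scatter), large and beyond the scatter, and the change here shortens the chain again. A large step to a lower number in this assay is therefore expected. Expected is a 12-fold lower number from compound 2 to compound 3 (1.09 log units; beyond the scatter). For compound 3 the estimated value is 1800 nM, with an expected range of 600 nM to 5500 nM.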

Compound 3, half-maximal inhibitory concentration: 2140 nM
Compound 3: the middle estimate sits 1.2-fold (0.08 log units) below what was measured, and the stated range covers the measured number.
By their numbers in this assay, from the lowest: compounds 1 and 3 (each within the scatter of the next); then compound 2.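

In this assay, replacing octyl with allyl removes the large rise seen with the longer chain, with a 10-fold lower number from compound 2 to compound 3 (1.01 log units; beyond the scatter) as the step. The double bond outside aromatic rings shows no separation from the shorter saturated chain at this place, with a 1.6-fold higher number from compound 1 to compound 3 (0.21 log units; within the scatter) as the step, so compound 1 and compound 3 cannot be told apart here. Nothing available gives a reason for either step. Open, on these data alone, are a butyl or hexyl chain, which would show where along the chain the number begins to rise, and a chain ending in an amine or a carboxylic acid.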